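The compounds below may be only part of what the source reports. "The series", "measured", "known", "first", "only" and "open" are said of these compounds alone.

Series notes. Compound 1 `COc1ccc(/C=N/NC(=O)c2ccc(N)cc2)cc1` gives 2.39 in a physicochemical assay for lipophilicity; a higher number here means a more lipophilic compound, a lower number a more polar compound. Compound 2 `COc1ccc(/C=N/NC(=O)c2ccc([N+](=O)[O-])cc2)cc1` gives 3.13 in this assay; the structural change is nitro in place of amino on an aromatic carbon, and the step measured is a number 0.74 log units higher from compound 1 to compound 2 (beyond the scatter). Compound 3 `Nc1ccc(C(=O)N/N=C/c2cccc([N+](=O)[O-])c2)cc1` gives 2.6 in this assay; how its core differs from the core of compound 1 is not broken down here. Compound 4 `O=C(N/N=C/c1cccc([N+](=O)[O-])c1)c1ccc([N+](=O)[O-])cc1` has not yet been measured in this assay. It differs from compound 3 by nitro in place of amino on an aromatic carbon, the same change, at the same place, as that made from compound 1 to compound 2. Because the earlier instance gave a number 0.74 log units higher from compound 1 to compound 2 (beyond the scatter), a step of similar size is expected here, namely a number 0.74 log units higher from compound 3 to compound 4 (beyond the scatter). The estimate for compound 4 in this assay is therefore 3.34, expected to fall between 3 and 3.7.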

Compound 4, partition coefficient: 3.33
Compound 4: the middle estimate sits 0.01 log units above what was measured; the range from low to high includes it.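

In this assay, nitro in place of amino on an aromatic carbon gives a number 0.73 log units higher from compound 3 to compound 4 (beyond the scatter) on the core of compound 3, and the same change gave a number 0.74 log units higher from compound 1 to compound 2 (beyond the scatter) on the core of compound 1, so the step carried across these two cores at a similar size. This rests on two pairs only, with the change para to a large group in both, and it does not show that the step holds on other cores or at other places. No measurement is at hand that accounts for the size of the step.

Open, going by these compounds, is how a carboxylic acid or a nitrile in the same place would compare with amino and nitro. Also open, on these data alone, is whether the step persists on a core carrying a longer chain or a tertiary amine.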